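This account rests on a few compounds, and the source may have more. Where it says the series, first, only, none or still open, it means among the compounds named here.

Measured so far in a functional assay on DLD-1 cells (Homo sapiens) for cytotoxicity, read by WST assay, with a stated time of 72 h; on this read-out higher numbers stand for weaker inhibition and lower numbers for stronger inhibition:

- compound 1 `CCN(CC)CCCOc1cc2ncnc(Nc3nc4ccc(C(=O)Nc5c(C)cccc5C)cc4s3)c2cc1OC` gives > 100000 nM, which is a limit of the assay and not a number.
- compound 2 `CCN(CC)CCCOc1cc2ncnc(Nc3nc4ccc(C(=O)Nc5c(C)cccc5Cl)cc4s3)c2cc1OC` gives 11700 nM.
- compound 3 `COc1cc2c(Nc3nc4ccc(C(=O)Nc5c(C)cccc5Cl)cc4s3)ncnc2cc1OCCCN1CCCC1` gives 60700 nM.

Compound 1 stands at the edge of what this assay can report; its value is only a limit, as the line the limit of > 100000 nM in this assay, at which 1 of the 3 values shown sits, records. Among the compounds with values here, the one step away from it that has been measured, an at least 8.5-fold lower number from compound 1 to compound 2 (0.93 log units; beyond the scatter), leaves the amine end of the chain untouched and changes a substituent on an aromatic ring instead.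

Compound 4 `COc1cc2c(Nc3nc4ccc(C(=O)Nc5c(C)cccc5C)cc4s3)ncnc2cc1OCCCN1CCCCC1C` differs from compound 1 only at that amine end: 2-methylpiperidin-1-yl in place of diethylamino on a saturated chain carbon, three bonds along the chain from an oxygen on an aromatic ring. The closest measured guide is a 5.2-fold higher number from compound 2 to compound 3 (0.72 log units; beyond the scatter), where a cyclic amine also replaced diethylamino on the same chain and the number went up. Within the data shown here, since compound 1 already sits at the limit, a further rise would most likely leave compound 4 beyond the limit as well, and no step toward a lower number is suggested by anything measured.

Compound 4 is therefore expected to show about 200000 nM, within a range of 60000 nM to 700000 nM. This expectation corresponds to a step that the limit leaves unreadable from compound 1 to compound 4.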

Compound 4, half-maximal inhibitory concentration: > 100000 nM
Compound 4: a limit, no number; the forecaster's own chance of this, stated with the estimate: 85%; the middle value lies beyond the limit too.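

Compound 4 and compound 1 both sit at a limit and give no number, so no step between them can be read in this assay: the limit of > 100000 nM in this assay, at which 2 of the 4 values shown sit.

The compounds shown leave open whether 2-methylpiperidin-1-yl in place of diethylamino changes the number at all, and in which direction.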